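Replacing the (2-methoxybenzyl)amino group of compound 3

This account rests on a few compounds, and the source may have more. Where it says the series, first, only, none or still open, it means among the compounds named here.

In a functional assay on cells (Homo sapiens) for cytotoxicity, read by MTT assay, with a stated time of 24 h (a lower number here means a stronger inhibitor, a higher number a weaker inhibitor), compound 3 `CCCCCCCCCCCCCCNC(=O)[C@H](CO)NCc1ccccc1OC` gives 100000 nM. Compound 1 `CCCCCCCCCCCCCCNC(=O)[C@H](CO)/N=C/c1cccc(C)c1` gives 82900 nM, so the two sit level, with a 1.2-fold higher number from compound 1 to compound 3 (0.08 log units; within the scatter). Compound 2 `CCCCCCCCCCCCCCNC(=O)[C@H](CO)/N=C/c1ccc(Cl)cc1` gives 27500 nM, the lowest number of the three, and the step to the remaining compound is a 3.6-fold higher number from compound 2 to compound 3 (0.56 log units; beyond the scatter).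

Compound 4 `CCCCCCCCCCCCCCNC(=O)[C@H](CO)/N=C/c1ccc(O)cc1` carries this change: a group of 9 heavy atoms (7 carbon, 1 nitrogen, 1 oxygen; one six-membered aromatic ring of carbon only) in place of a group of 10 heavy atoms (8 carbon, 1 nitrogen, 1 oxygen; one six-membered aromatic ring of carbon only), on a saturated chain carbon bound to a carbonyl carbon and a saturated chain carbon. The (2-methoxybenzyl)amino group leaves, and the entering group brings 1 double bond outside aromatic rings, as in compound 1 and compound 2. Those two compounds therefore bear most directly on the change, yet they do not agree: one matches compound 3 and the other does not. The ring group also matters, as a 3.0-fold lower number from compound 1 to compound 2 (0.48 log units; beyond the scatter) shows. Among the compounds with values here, no measured compound carries the ring group of compound 4.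

A modest drop is therefore expected, landing between compound 2 and compound 1, with the expected step being a 2.2-fold lower number from compound 3 to compound 4 (0.35 log units; beyond the scatter). Compound 4 is estimated at 45000 nM, with an expected range of 18000 nM to 100000 nM.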

Compound 4, half-maximal inhibitory concentration: 19300 nM
The estimate for compound 4 lay 2.3-fold (0.37 log units) above the measured number, within the range that was stated.
By their numbers in this assay, from the lowest: compounds 4 and 2 (each within the scatter of the next); then compounds 1 and 3 (each within the scatter of the next).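

With the 4-hydroxyphenyl ring on the double-bonded group, the change at this position gives a clear gain in this assay, a 5.2-fold lower number from compound 3 to compound 4 (0.71 log units; beyond the scatter), so the entering linkage does not by itself hold the number level with compound 3, as compound 1 alone might have suggested. Hydroxy and chloro cannot be told apart here, a 1.4-fold lower number from compound 2 to compound 4 (0.15 log units; within the scatter), whereas the ring of compound 1 stands apart, a 4.3-fold lower number from compound 1 to compound 4 (0.63 log units; beyond the scatter). No evidence is available to explain these steps. The compounds shown leave open how much of the step belongs to the double bond and how much to the ring, since no ring group appears with both linkages. Going by these compounds, whether an amine or a carboxylic acid on the ring would match hydroxy and chloro also stays open.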